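The source may report more compounds than this note shows. Statements on the series, on what has been measured and on what is new or still open speak of the compounds shown alone.

In a functional assay on HeLa cells (Homo sapiens) for cytotoxicity, read by neutral red uptake, with a stated time of 3 days (on this read-out higher numbers stand for weaker inhibition and lower numbers for stronger inhibition), compound 2 `COc1c(F)c(N)c2c(=O)cc(-c3ccc(N)c(F)c3)oc2c1F` gives 34000 nM. Compound 1 `C[S+]([O-])c1c(F)c(N)c2c(=O)cc(-c3ccc(N)c(F)c3)oc2c1F` yields only a limit, > 100000 nM. Compound 3 `[N-]=[N+]=Nc1c(F)c(N)c2c(=O)cc(-c3ccc(N)c(F)c3)oc2c1F` gives 1200 nM, the lowest number of the three. Compound 4 `CCCCCC(=O)OCc1c(F)c(N)c2c(=O)cc(-c3ccc(N)c(F)c3)oc2c1F` carries ((pentylcarbonyl)oxy)methyl in place of azido on an aromatic carbon, ortho to two fluoro groups (((pentylcarbonyl)oxy)methyl in place of azido on an aromatic carbon). The measured steps at this same place favour azido: the large 28-fold lower number from compound 2 to compound 3 (1.45 log units; beyond the scatter) and the large at least 83-fold lower number from compound 1 to compound 3 (1.92 log units; beyond the scatter). Neither replaced group resembles the entering one, so these steps give direction more than size. In this assay, a sizeable step towards a higher number is therefore expected. The expected change is a 10-fold higher number from compound 3 to compound 4 (1.00 log units; beyond the scatter). Compound 4 is estimated at 12000 nM, within an expected range of 2000 nM to 70000 nM.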

Compound 4, half-maximal inhibitory concentration: 34000 nM
The estimate for compound 4 lay 2.8-fold (0.45 log units) below the measured number; measured number inside the range.
By their numbers in this assay, from the lowest: compound 3; then compounds 2 and 4 (each within the scatter of the next). At a limit, above all of these: compound 1.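

In this assay, ((pentylcarbonyl)oxy)methyl does not keep the low number seen with azido on this aromatic carbon, with a 28-fold higher number from compound 3 to compound 4 (1.45 log units; beyond the scatter). Against methoxy, the same group shows no change at the digits printed from compound 2 to compound 4 (within the scatter), so the two are not told apart here despite their different heavy-atom counts. The step with an at least 2.9-fold lower number from compound 1 to compound 4 (0.46 log units; beyond the scatter) is only a bound: the limit of > 100000 nM in this assay, at which 1 of the 4 values shown sits.

Going by these compounds, whether a small amine, a free hydroxymethyl or a shorter ester at this place would lie nearer compound 3 or compound 4 remains open.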